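The compounds below may be only part of what the source reports. "The series", "measured", "known", "first", "only" and "open" are said of these compounds alone.

In a toxicity assay on Vero cells (Chlorocebus sabaeus) for cytotoxicity, read by MTT assay (on this read-out lower numbers stand for stronger inhibition and higher numbers for weaker inhibition), compound 1 (`CCOC(=O)NC(=O)c1ccsc1NC(=O)c1ccc(S(=O)(=O)N2CCCCCC2)cc1`) gives 3.42 ug/mL and compound 2 (`CCOC(=O)NC(=O)c1ccsc1NC(=O)c1ccc(S(=O)(=O)N2CCC(OC)CC2)cc1`) gives 21 ug/mL as the higher of the two numbers. Compound 3 (`CCOC(=O)NC(=O)c1ccsc1NC(=O)c1ccc(S(=O)(=O)Nc2ccccc2)cc1`) differs from compound 2 by anilino in place of 4-methoxypiperidin-1-yl on a sulfonyl sulfur and carries anilino in place of 4-methoxypiperidin-1-yl on a sulfonyl sulfur. Among the measured compounds shown here, the one measured step that bears on this change (a 6.1-fold higher number from compound 1 to compound 2 (0.79 log units; beyond the scatter)) was modest and sat on the same sulfonyl sulfur, so a step of similar or smaller size towards lower numbers is expected in this assay here. The expected move (a 2.1-fold lower number from compound 2 to compound 3 (0.32 log units; beyond the scatter)) stays within that size. For compound 3 the estimated value is 10 ug/mL with an expected range from 3 ug/mL to 35 ug/mL on this read-out.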

Compound 3, half-maximal inhibitory concentration: 14.5 ug/mL
Beside the measured number, compound 3's estimate is 1.5-fold (0.16 log units) below it; the measured number falls inside the stated range.
By their numbers in this assay, from the lowest: compound 1; then compounds 3 and 2 (each within the scatter of the next).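

In this assay, anilino in place of 4-methoxypiperidin-1-yl gives a 1.4-fold lower number from compound 2 to compound 3 (0.16 log units; within the scatter) so an aromatic ring with a hydrogen-bond donor on the sulfonyl sulfur cannot be told apart from that non-aromatic ring with its methoxy group. Anilino in place of azepan-1-yl gives a 4.2-fold higher number from compound 1 to compound 3 (0.63 log units; beyond the scatter) so the gap first seen with compound 2 appears again with a second, quite different group. Nothing at hand explains either result.

Going by these compounds, whether morpholine or pyrrolidine on the sulfonyl sulfur would fall with compound 1 or with compound 2 and compound 3 stays open. So does whether a chloro or methoxy group on the anilino ring would shift the number at all.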